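The compounds below may be only part of what the source reports. "The series", "measured", "known", "first", "only" and "open" are said of these compounds alone.

In an ADME assay on cells (Homo sapiens) for cytotoxicity, read by resazurin assay, with a stated time of 5 days (a higher number here means that more compound is tolerated, a lower number that less compound is tolerated), compound 3 `COc1ccc(-c2nc(CSc3cccc(Cl)c3Cl)nc3ccsc23)cn1` gives > 50000 nM, which is a limit and not a number. Compound 2 `COc1ccc(-c2nc(COc3cccc(Cl)c3)nc3ccsc23)cn1` also gives only a limit, > 50000 nM. Compound 1 `COc1ccc(-c2nc(CC(=O)c3cccc(Cl)c3)nc3ccsc23)cn1` gives a true number, 30000 nM. Compound 4 `COc1ccc(-c2nc(CNc3cccc(Cl)c3)nc3ccsc23)cn1` carries (3-chlorophenyl)amino in place of (2,3-dichlorophenyl)sulfanyl, on a saturated chain carbon bound to an aromatic carbon: (3-chlorophenyl)amino in place of (2,3-dichlorophenyl)sulfanyl on a saturated chain carbon bound to an aromatic carbon. Changes at this same place have given an at least 1.6-fold higher number from compound 1 to compound 2 (0.22 log units; that floor lies within the scatter), an at least 1.6-fold higher number from compound 1 to compound 3 (0.22 log units; that floor lies within the scatter) and a step that the two limits leave unreadable from compound 2 to compound 3. The measured values gather at the limit of > 50000 nM in this assay, at which 2 of the 3 values shown sit. No step beyond the scatter is therefore expected in this assay, in either direction. The expected step is an at least 1.2-fold lower number from compound 3 to compound 4 (0.09 log units; that floor lies within the scatter). Compound 4 is estimated at 40000 nM, with an expected range of 15000 nM to 60000 nM.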

Compound 4, half-maximal cytotoxic concentration: > 50000 nM
Compound 4 was reported as a limit (the forecaster's own chance of this, stated with the estimate: 45%); middle value at least 1.2-fold (0.09 log units) from the limit.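

Where (2,3-dichlorophenyl)sulfanyl has no hydrogen-bond donor, (3-chlorophenyl)amino has one, yet in this assay compound 4 still gives only a limit and not a number: the limit of > 50000 nM in this assay, at which 3 of the 4 values shown sit. The one readable step is an at least 1.6-fold higher number from compound 1 to compound 4 (0.22 log units; that floor lies within the scatter), so compound 1 remains the only compound here with a true number. The steps from compound 2 and from compound 3 to compound 4 cannot be read.

As far as these compounds go, how compounds 2, 3 and 4 rank beyond the limit stays open. Also open, from the compounds shown here alone, is whether a carboxylic acid or a longer chain at this place would give a true number.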